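A few compounds are considered here, and "the series" means these few. Any claim that something is new, unique, unknown or untested is made for them only; others in the source may bear on it.

Compound 1 `CCC(=O)N(c1cccc(Br)c1)C1CCCC1N(C)C` and compound 2 `CCC(=O)N(c1ccc(Br)cc1)C1CCCC1N(C)C` are built from the same atoms joined differently; the difference between the two cores is not broken down here. In a functional assay on the whole organism for positive allosteric modulation, with Mus musculus as the target (a higher number here means that more compound is needed for the effect, a lower number that less compound is needed), compound 1 gives 2 mg/kg. For compound 2 this assay returns only a limit, > 50 mg/kg, which is the limit of > 50 mg/kg in this assay, at which 1 of the 3 values shown sits. Compound 3 `CCC(=O)N(c1cccc(C(F)(F)F)c1)C1CCCC1N(C)C` differs from compound 1 by trifluoromethyl in place of bromo on an aromatic carbon, and in this assay compound 3 gives 0.9 mg/kg, a change that amounts to a 2.2-fold lower number from compound 1 to compound 3 (0.35 log units; beyond the scatter). Compound 4 `CCC(=O)N(c1ccc(C(F)(F)F)cc1)C1CCCC1N(C)C` stands to compound 2 as compound 3 stands to compound 1, carrying (trifluoromethyl in place of bromo on an aromatic carbon). The two places are not the same word for word: in compound 3 the group sits meta to a large group, in compound 4 para to a large group, so the change is the same kind of change rather than the same. In this assay a step of an at least 1.2-fold lower number from compound 2 to compound 4 (0.09 log units; that floor lies within the scatter) is expected, resting on the measured 2.2-fold lower number from compound 1 to compound 3 (0.35 log units; beyond the scatter). Since compound 2 gave only a limit, the outcome for compound 4 may well be a limit as well. For compound 4 the estimate in this assay is 40 mg/kg, with a range from 15 mg/kg to 100 mg/kg.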

Compound 4, dose for half-maximal effect: 10 mg/kg
Compound 4: middle estimate off by 4.0-fold (0.60 log units), on the high side, outside the stated range (below it).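

In this assay, trifluoromethyl in place of bromo on an aromatic carbon, para to a large group, gives an at least 5.0-fold lower number from compound 2 to compound 4 (0.69 log units; beyond the scatter), so the change lowers the number on both cores: the same change on two cores in this assay, a 2.2-fold lower number (0.35 log units; beyond the scatter) from compound 1 to compound 3 and an at least 5.0-fold lower number (0.69 log units; beyond the scatter) from compound 2 to compound 4; the limit leaves it open whether they differ. Compound 2 stands only at a limit of the assay, > 50 mg/kg, and not at a number: the limit of > 50 mg/kg in this assay, at which 1 of the 4 values shown sits. On these data alone, the direction of the change thus carries from the core of compound 1 to the core of compound 2, but the size of the step on the second core stays unknown, and two pairs of compounds make no rule for the wider series.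

Still open, as far as these compounds go, is whether the same direction holds for other groups in place of bromo on either core, such as a nitrile, a chloro or a methoxy group. Also open, from the compounds shown here alone, is whether the step survives a longer chain on the amide carbonyl or a different amine in place of the dimethylamino group.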